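The source may hold more compounds than are shown below. What is called first, only, known or untested is meant among the compounds shown, and "the series" means these compounds.

Compound 1 `O=C(Cn1c(=O)oc2ccccc21)Nc1cc(C(F)(F)F)ccc1Cl`: 15.4%
Compound 2 `O=C(Cn1c(=O)oc2cc(Cl)ccc21)Nc1cc(C(F)(F)F)ccc1Cl`: 12.1%

In an ADME assay on RAW264.7 cells (Mus musculus) for cytotoxicity, read by MTT assay, with a stated time of 72 h, tested at 100 uM (on this read-out higher numbers stand for a stronger effect at the one concentration tested and lower numbers for a weaker effect), compound 1 gives 15.4% and compound 2 gives 12.1%. These two numbers sit side by side, since the step of a number 3.3 percentage points lower from compound 1 to compound 2 (within the scatter) stays within the scatter, so neither compound can be called more or less active than the other.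

Compound 3 `O=C(Cn1c(=O)oc2cc([N+](=O)[O-])ccc21)Nc1cc(C(F)(F)F)ccc1Cl` differs from compound 2 in one place: nitro in place of chloro on an aromatic carbon. Among the compounds with values here, the only measured step that touches this place is a number 3.3 percentage points lower from compound 1 to compound 2 (within the scatter), which changed nothing beyond the scatter, so it gives little guidance. With no evidence of a real shift, the expected step is a number 0.9 percentage points higher from compound 2 to compound 3 (within the scatter), essentially none beyond the scatter. Compound 3 is therefore estimated at 13%, with a range from 3% to 28%.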

Compound 3, a percentage reported as inhibition, at one concentration (the size of the read-out at that concentration, not a potency): 31.6%
Beside the measured number, compound 3's estimate is 18.6 percentage points below it, and the stated range ends below it.
By their numbers in this assay, from the lowest: compounds 2 and 1 (each within the scatter of the next); then compound 3.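

In this assay this aromatic carbon proves able to shift the read-out: nitro in place of chloro gives a number 19.5 percentage points higher from compound 2 to compound 3 (beyond the scatter) and nitro in place of hydrogen gives a number 16.2 percentage points higher from compound 1 to compound 3 (beyond the scatter) while chloro in place of hydrogen moved nothing beyond the scatter. Among these three compounds, then, the outcome depends on which group enters, not merely on whether a group is there. Nothing shown here explains the nitro result. On these data alone, whether an amine or a carboxylic acid at this place would stay with chloro or rise with nitro remains open.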